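Dimethyl benzoxazole in place of benzoxazole: an expectation

The source may hold more compounds than are shown below. What is called first, only, known or untested is meant among the compounds shown, and "the series" means these compounds.

Measured compounds:
Compound 1, `O=C(O)CCCSCCN1C(=O)CC[C@@H]1/C=C/[C@@H](O)Cc1cccc(-c2ccc3[nH]ccc3c2)c1`: > 10000 nM
Compound 2, `O=C(O)c1csc(SCCN2C(=O)CC[C@@H]2/C=C/[C@@H](O)Cc2cccc(-c3nc4ccccc4o3)c2)n1`: > 10000 nM

In an assay on CHO cells for displacement of a labelled ligand from prostaglandin E2 receptor EP1 subtype (Mus musculus), read by scintillation counting, with a stated time of 20 min (on this read-out higher numbers stand for weaker inhibition and lower numbers for stronger inhibition), compound 2 gives > 10000 nM, which is a limit of the assay and not a number. Compound 1 gives > 10000 nM in this assay, likewise a limit. Compound 2 therefore stands at the limit of > 10000 nM in this assay, at which 2 of the 2 values shown sit; no measured value here separates it from compound 1, and nothing shows where below or above the limit either truly lies.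

The unmeasured compound 3, `Cc1cc(C)c2oc(-c3cccc(C[C@H](O)/C=C/[C@H]4CCC(=O)N4CCSc4nc(C(=O)O)cs4)c3)nc2c1`, differs from compound 2 by 5,7-dimethyl-1,3-benzoxazol-2-yl in place of 1,3-benzoxazol-2-yl on an aromatic carbon. Within the data shown here, no step between two measured compounds is available, so the size of such a change cannot be read from a measured pair. With compound 2 at a limit, the step can only be given as an expectation: it is expected to be a step that the limit leaves unreadable from compound 2 to compound 3, with no direction beyond the scatter that the data would support. Compound 3 is expected to give 15000 nM, between 3000 nM and 60000 nM, and most probably again only a limit.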

Compound 3, inhibition constant: 3200 nM
The estimate for compound 3 lay 4.7-fold (0.67 log units) above the measured number; the range from low to high includes it.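

In this assay, putting 5,7-dimethyl-1,3-benzoxazol-2-yl in place of 1,3-benzoxazol-2-yl on the aromatic carbon gives an at least 3.1-fold lower number from compound 2 to compound 3 (0.49 log units; beyond the scatter). The earlier compounds both sat at a limit and so could not show whether this part of the molecule moves the read-out at all; compound 3 is the first of the compounds shown to give a number, and it shows that the dimethyl substitution on the benzoxazole alone, with the rest of compound 2 unchanged, is enough to do so. Compound 2 gives a limit and not a number, so this step has a bound but no exact size: the limit of > 10000 nM in this assay, at which 2 of the 3 values shown sit.

The compounds shown leave open whether 5-methyl-1,3-benzoxazol-2-yl or 7-methyl-1,3-benzoxazol-2-yl alone would carry the step, and whether chloro or methoxy groups in place of the methyl groups would do the same. They also leave open whether the dimethyl benzoxazole would give a similar step with the butanoic acid thioether chain of compound 1 in place of the thiazole carboxylic acid chain.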